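Cyclobutyl for sec-Butyl: What Compound 3 Might Show

The source may report more compounds than this note shows. Statements on the series, on what has been measured and on what is new or still open speak of the compounds shown alone.

Two measured compounds share one core. Compound 1 `CC1=C(C(=O)CC(C)C)C(c2ccco2)NC(=O)N1` carries isobutyl on a carbonyl carbon, and in an assay on membranes from CHO cells for displacement of a labelled ligand from adenosine receptor A1 (Homo sapiens), read by scintillation counting, with a stated time of 60 min, tested at 1 uM (on this read-out lower numbers stand for less inhibition and higher numbers for more inhibition at the one concentration tested (going by the name of the read-out)), compound 1 gives 16%. Compound 2 `CCC(C)OC(=O)C1=C(C)NC(=O)NC1c1ccco1` has sec-butoxy in place of isobutyl on a carbonyl carbon, and in this assay compound 2 gives 6%. The step of a number 10 percentage points lower from compound 1 to compound 2 (within the scatter) stays within the scatter, so the two read-outs cannot be told apart. Compound 2 holds the lower of the two numbers, with compound 1 nearest and within the scatter.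

Compound 3 `CC1=C(C(=O)OC2CCC2)C(c2ccco2)NC(=O)N1` differs from compound 2 by cyclobutyl in place of sec-butyl on an oxygen next to a carbonyl group. For the measured compounds named here, no measured step touches the group on the oxygen next to a carbonyl group; the single measured step concerns another place and stays within the scatter. Nothing in the data points to a move beyond the scatter in either direction. The expected step for compound 3 is a number 2 percentage points higher from compound 2 to compound 3 (within the scatter), within the scatter. Compound 3 is estimated at 8%, with a range from 0% to 22%.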

Compound 3, a percentage reported as inhibition, at one concentration (the size of the read-out at that concentration, not a potency): 19%
Compound 3: the middle estimate sits 11 percentage points below what was measured, within the range that was stated.
By their numbers in this assay, from the lowest: compounds 2, 1 and 3 (each within the scatter of the next, the first and the last beyond it).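

In this assay, for the compounds shown here, the group on an oxygen next to a carbonyl group is changed for the first time, and cyclobutyl in place of sec-butyl gives a number 13 percentage points higher from compound 2 to compound 3 (beyond the scatter) as a step, so this position can move the read-out even when 4 carbons leave and 4 carbons enter. The one thing that differs in the count is the four-membered ring of carbon that cyclobutyl brings. Cyclobutyloxy in place of isobutyl on a carbonyl carbon gives a number 3 percentage points higher from compound 1 to compound 3 (within the scatter) as a step, so these two compounds cannot be told apart, and nothing measured here gives a reason for the step at the oxygen.

On these data alone, what stays open is how cyclopentyl, cyclopropyl or a longer chain on the same oxygen would read. As far as these compounds go, whether an amine at this place would hold the number also stays open.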